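Cyclopropylmethoxy on the aryl piperazine: compound 2 to compound 3

This account rests on a few compounds, and the source may have more. Where it says the series, first, only, none or still open, it means among the compounds named here.

Two compounds from this series have numbers in a functional assay on aorta for antagonist activity at Alpha-1D adrenergic receptor (Rattus norvegicus); a higher number here means weaker binding, a lower number tighter binding. Compound 1 `COc1ccccc1N1CCN(CCCSc2ccccc2C(=O)N(C)C)CC1` gives 12.6 nM in this assay. Compound 2 `CN(C)C(=O)c1cccnc1NCCCN1CCN(c2ccccc2)CC1` gives 15.9 nM in this assay. Among the measured compounds shown here, the two values sit within the scatter of each other, so the data do not separate compound 1 from compound 2 in this assay; compound 2 is simply the one whose number happens to stand higher of the two. The two compounds also differ in more than one place, so no single step can be read from them.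

The next compound, compound 3 `CN(C)C(=O)c1cccnc1NCCCN1CCN(c2ccccc2OCC2CC2)CC1`, keeps the core of compound 2 and differs from it in one place: cyclopropylmethoxy in place of hydrogen on an aromatic carbon. The change adds cyclopropylmethoxy on an aromatic carbon of a six-membered aromatic ring of carbon only, ortho to a large group. For the measured compounds named here, no measured pair tells how this kind of change moves the numbers in this assay, so the step from compound 2 to compound 3 is expected to be small and toward a lower number, or nothing beyond the scatter, as a 1.8-fold lower number from compound 2 to compound 3 (0.25 log units; within the scatter). Compound 3 is therefore estimated at 9 nM in this assay, within a range of 3 nM to 27 nM.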

Compound 3, dissociation constant: 10 nM
For compound 3 the middle estimate is 1.1-fold (0.05 log units) below the measured one; the measured number falls inside the stated range.
By their numbers in this assay, from the lowest: compounds 3, 1 and 2 (each within the scatter of the next).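

Among the compounds shown here, compound 3 gives the first reading of a change made in one place. In this assay the addition of cyclopropylmethoxy on an aromatic carbon of the six-membered aromatic ring of carbon only, ortho to a large group, appears as a 1.6-fold lower number from compound 2 to compound 3 (0.20 log units; within the scatter) and so leaves the two compounds inseparable. This position therefore takes a group of 5 heavy atoms, with its three-membered non-aromatic ring of carbon only, and the data show no loss or gain of binding that can be told apart from repeated measurement. Nothing available here bears on why the number stays within the scatter.

A single step at a single place leaves open whether the outcome belongs to cyclopropylmethoxy itself or would be shared by other groups on the same carbon, such as a hydroxyl, an amine or a longer alkoxy chain. It also leaves open whether the same group would behave in the same way on another carbon of this ring, or on the core of a compound with a different linking chain.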